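The compounds below may be only part of what the source reports. "The series", "measured", "known", "first", "only" and "open" are said of these compounds alone.

Measured in an ADME assay on NIH3T3 cells (Mus musculus) for cytotoxicity, read by MTT assay, with a stated time of 24 h; on this read-out higher numbers stand for weaker inhibition and lower numbers for stronger inhibition:
compound 1 `O=C(CSc1nnc(COc2ccc3c(c2)CCCC3)o1)Nc1nc2ccc([N+](=O)[O-])cc2s1`: 336000 nM
compound 2 `Cc1ccc2nc(NC(=O)CSc3nnc(COc4ccc5c(c4)CCCC5)o3)sc2c1`: > 403000 nM

Compound 2 has no exact number, and its > 403000 nM is a limit of the assay. Compound 3 `CCOc1ccc2nc(NC(=O)CSc3nnc(COc4ccc5c(c4)CCCC5)o3)sc2c1` carries ethoxy in place of methyl on an aromatic carbon, (ethoxy in place of methyl on an aromatic carbon). Among the compounds with values here, one measured step bears on this change, and it replaces a different group at the same place: an at least 1.1-fold higher number from compound 1 to compound 2 (0.07 log units; that floor lies within the scatter). Within the data shown here, with that as the only guide, no step beyond the scatter is expected in this assay. The expected step is a number no higher from compound 2 to compound 3 (the limit leaves the size open). The estimated value for compound 3 is 400000 nM, with an expected range of 180000 nM to 900000 nM.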

Compound 3, half-maximal inhibitory concentration: > 403000 nM
Compound 3: only a limit was reported; the forecaster's own chance of this, stated with the estimate: 55%; middle value at least 1.0-fold (0.00 log units) from the limit.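

In this assay compound 3, with ethoxy at this position, gives > 403000 nM, which is a limit and not a number. Ethoxy in place of nitro gives an at least 1.1-fold higher number from compound 1 to compound 3 (0.07 log units; that floor lies within the scatter), while the step between the methyl and ethoxy compounds cannot be read. A second group at this position thus ends at the same limit, and the comparison stops there: the limit of > 403000 nM in this assay, at which 2 of the 3 values shown sit.

From the compounds shown here alone, what an amine or a carboxylic acid at this position would give in this assay stays open. So does how far compound 2 and compound 3 really lie from compound 1.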